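The compounds below may be only part of what the source reports. "The series", "measured", "known", "first", "only" and "open" are said of these compounds alone.

For the measured compounds named here, compound 1 `COc1ccc(-c2ccc3c(O)cccc3c2)cc1` gives 28% in an assay for binding affinity to 17-beta-hydroxysteroid dehydrogenase type 1 (Homo sapiens), with a stated time of 20 min, tested at 1 uM (a higher number here means more inhibition at the concentration tested (going by the name of the read-out), a lower number less inhibition), the lower of the two numbers measured so far. Going by the values given here, compound 2 `CS(=O)(=O)Nc1ccc(-c2ccc3c(O)cccc3c2)cc1`, which carries methanesulfonamido in place of methoxy on an aromatic carbon, gives 52% in this assay, and the step of a number 24 percentage points higher from compound 1 to compound 2 (beyond the scatter) is the only measured step available. Compound 3 `CNC(=O)c1ccc(-c2ccc3c(O)cccc3c2)cc1` has not been measured and differs from compound 1 by methylcarbamoyl in place of methoxy on an aromatic carbon. That measured step bears on the new change because a number 24 percentage points higher from compound 1 to compound 2 (beyond the scatter) shows that exchanging methoxy for a group bringing one hydrogen-bond donor raised inhibition modestly, and methylcarbamoyl likewise brings one hydrogen-bond donor. The two groups are not the same, so a somewhat smaller rise is expected for compound 3, with an estimated step of a number 17 percentage points higher from compound 1 to compound 3 (beyond the scatter) in this assay. Compound 3 is therefore expected to give about 45% in this assay, within a range from 25% to 65%.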

Compound 3, a percentage reported as inhibition, at one concentration (the size of the read-out at that concentration, not a potency): < 10%
Compound 3: only a limit was reported; the forecaster's own chance of this, stated with the estimate: 0%; middle value at least 35 percentage points from the limit.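

In this assay, methylcarbamoyl on this aromatic carbon, para to a large group, moves inhibition the opposite way to methanesulfonamido, giving a number at least 18 percentage points lower from compound 1 to compound 3 (beyond the scatter) and a number at least 42 percentage points lower from compound 2 to compound 3 (beyond the scatter). A hydrogen-bond donor on this carbon therefore does not by itself raise inhibition, and the group that carries it matters, which compound 1 and compound 2 alone could not show. Compound 3 has a limit rather than a number here, so both steps are bounds and their full size stays unknown because of it: the limit of < 10% in this assay, at which 1 of the 3 values shown sits.

On these data alone, what remains open is which part of methylcarbamoyl goes with the drop, and a primary carboxamide or a carboxylic acid on this carbon would bear on that. Ethanesulfonamido would show whether the rise seen with methanesulfonamido survives a longer chain.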